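Extending a hydrazide: from compound 3 toward compound 4

A few compounds are considered here, and "the series" means these few. Any claim that something is new, unique, unknown or untested is made for them only; others in the source may bear on it.

Of the compounds shown here, three built on a shared core have been tested in a functional assay on the whole organism for inhibition, with Mus musculus as the target, read by paw edema, with a stated time of 180 min, at a dose of 100 mg/kg by the oral route; a higher number here means a stronger effect of the compound at the dose given, a lower number a weaker effect. Compound 1 `CNc1nnc(Cn2c(=O)oc3ccc(C)cc32)s1` gives 21.4%, and compound 2 `Cc1ccc2oc(=O)n(Cc3n[nH]c(=S)n3C)c2c1` gives 11.8%. Compound 3 `Cc1ccc2oc(=O)n(CC(=O)NN)c2c1`, which carries a hydrazide on the core, gives 70.5%, the highest of the three numbers. Its nearest neighbour is compound 1, a number that is far lower, and compound 2 lies even further below; both gaps are well beyond the usual scatter of repeated measurements.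

Compound 4 `CCCNC(=S)NNC(=O)Cn1c(=O)oc2ccc(C)cc21` is not yet measured. It differs from compound 3 in one place: a group of 6 heavy atoms (4 carbon, 1 nitrogen, 1 sulfur; no ring) in place of a hydrogen atom, on an amine nitrogen. The hydrazide of compound 3 is thus kept but extended, rather than closed into a ring as in compound 1 and compound 2.

Among the measured compounds shown here, no step between measured compounds is known, so the size of the step must be guessed from the three values alone. The two ring-bearing compounds, compound 1 and compound 2, sit far below compound 3; the open-chain extension in compound 4 seems more modest, so a drop in this assay is expected, but a smaller one. Compound 4 is estimated to give 50%, with a range from 25% to 72%. This estimate means an expected step of a number 20.5 percentage points lower from compound 3 to compound 4 (beyond the scatter), a fall somewhat beyond the scatter.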

Compound 4, a percentage reported as inhibition, in the whole organism at one dose (the size of the read-out at that dose, not a potency): 46.1%
Estimate against measurement, compound 4: 3.9 percentage points above; low and high end bracket the measured number.
By their numbers in this assay, from the lowest: compounds 2 and 1 (each within the scatter of the next); then compound 4; then compound 3.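

In this assay, among the compounds shown here, extending the hydrazide with the group of 6 heavy atoms on its amine nitrogen gives a number 24.4 percentage points lower from compound 3 to compound 4 (beyond the scatter) and is the first single change in this set whose size can be read. The fall shows that this amine nitrogen is not indifferent to what it carries, since exchanging a hydrogen atom for this open chain costs more than the usual scatter, yet compound 4 still gives 46.1% at the one dose tested, so substitution at this place does not remove the read-out altogether. Nothing measured here shows why the number falls.

A single change brings in the propyl chain, the extra nitrogen and the sulfur together, so it remains open which of these parts accounts for the step, and a methyl group on the same nitrogen, or the same chain ending in a carbonyl oxygen instead of sulfur, would help to separate them. Also open, as far as these compounds go, is whether a longer chain or a phenyl ring at the far end would lower the number further or restore it.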